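The source may report more compounds than this note shows. Statements on the series, on what has been measured and on what is new or still open speak of the compounds shown alone.

Compound 3 `COc1cc(Br)ccc1Nc1cc(NC(=O)Nc2c(Cl)cccc2Cl)ncn1` gives the lowest number of the three in a functional assay on HCC827 cells (Homo sapiens) for inhibition, read by MTT assay, with a stated time of 48 h, tested at 10 uM (a lower number here means less inhibition, a higher number more inhibition at the concentration tested (going by the name of the read-out)), with 42.7%. Its nearest neighbour is compound 2 `Cc1cc(F)cc(Nc2cc(NC(=O)Nc3c(Cl)cccc3Cl)ncn2)c1` at 49.1%, a step of a number 6.4 percentage points lower from compound 2 to compound 3 (within the scatter) that stays within the scatter; compound 1 `COc1ccc(F)cc1Nc1cc(NC(=O)Nc2c(Cl)cccc2Cl)ncn1`, at 78%, stands furthest away, the step of a number 35.3 percentage points lower from compound 1 to compound 3 (beyond the scatter) lying beyond it. Compound 4 `COc1ccc(Br)cc1Nc1cc(NC(=O)Nc2c(Cl)cccc2Cl)ncn1` changes the same aryl group: 5-bromo-2-methoxyphenyl in place of 4-bromo-2-methoxyphenyl on a nitrogen on an aromatic ring. The steps of a number 35.3 percentage points lower from compound 1 to compound 3 (beyond the scatter) and a number 28.9 percentage points lower from compound 1 to compound 2 (beyond the scatter) show that this position carries sizeable movement. As the entering 5-bromo-2-methoxyphenyl carries the 5-substituted 2-methoxyphenyl pattern of compound 1, whose value is 78%, a rise beyond the scatter is expected for compound 4, of about a number 19.3 percentage points higher from compound 3 to compound 4 (beyond the scatter). The estimate for compound 4 is 62%, between 42% and 80%.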

Compound 4, a percentage reported as inhibition, at one concentration (the size of the read-out at that concentration, not a potency): 53%
Beside the measured number, compound 4's estimate is 9 percentage points above it; low and high end bracket the measured number.
By their numbers in this assay, from the lowest: compounds 3, 2 and 4 (each within the scatter of the next, the first and the last beyond it); then compound 1.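

Moving the bromo alone on the same aryl group still shifts the read-out in this assay: a number 10.3 percentage points higher from compound 3 to compound 4 (beyond the scatter), so where the bromo sits counts at this position. With the substitution pattern held, exchanging the halogen also counts, with bromo in place of fluoro giving a number 25 percentage points lower from compound 1 to compound 4 (beyond the scatter). The 5-bromo-2-methoxyphenyl and 3-fluoro-5-methylphenyl groups are not separated, with a number 3.9 percentage points higher from compound 2 to compound 4 (within the scatter). Nothing available accounts for these steps. Open, from the compounds shown here alone, is how an amine or a carboxylic acid in place of the halogen, or a longer alkoxy chain in place of the methoxy, would read.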